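This account rests on a few compounds, and the source may have more. Where it says the series, first, only, none or still open, it means among the compounds named here.

Values measured so far in a functional assay on IMR-32 cells (Homo sapiens) for antiproliferative activity, read by sulforhodamine B assay, with a stated time of 48 h (on this read-out lower numbers stand for stronger inhibition and higher numbers for weaker inhibition), are as follows:
- compound 1 `COc1ccc(C[C@@H](O)/C=C/C=C/C(=O)N2CCN(C)CC2)cc1OC` gives 18900 nM
- compound 2 `CCN1CCN(C(=O)/C=C/C=C/[C@H](O)Cc2ccc(OC)c(OC)c2)CC1` gives 10800 nM

Compound 2 stands level with compound 1, with no order between them. Among the measured compounds shown here, the only measured step is a 1.8-fold lower number from compound 1 to compound 2 (0.24 log units; within the scatter) with methyl in place of hydrogen on a saturated chain carbon bound to an amine nitrogen in a ring.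

Compound 3 `COc1ccc(C[C@@H](O)/C=C/C=C/C(=O)N2CCN(c3ncccn3)CC2)cc1OC` departs from compound 2 by pyrimidin-2-yl in place of ethyl on an amine nitrogen in a ring. For the measured compounds named here, no measured compound carries pyrimidin-2-yl, so that one step is a weak guide and gives no direction. No step beyond the scatter is therefore expected in this assay and the expected change is a 1.1-fold lower number from compound 2 to compound 3 (0.03 log units; within the scatter) as a loose estimate. For compound 3 the estimated value is 10000 nM with an expected range from 3000 nM to 35000 nM in this read-out.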

Compound 3, half-maximal inhibitory concentration: 10800 nM
Estimate against measurement, compound 3: 1.1-fold (0.03 log units) below, and the stated range covers the measured number.
By their numbers in this assay, from the lowest: compounds 2, 3 and 1 (each within the scatter of the next).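

The amine nitrogen in the ring now carries pyrimidin-2-yl, a six-membered aromatic ring, rather than a small alkyl group, and in this assay the swap from ethyl gives no change at the digits printed from compound 2 to compound 3 (within the scatter), while the swap from methyl gives a 1.8-fold lower number from compound 1 to compound 3 (0.24 log units; within the scatter). Methyl, ethyl and pyrimidin-2-yl therefore fall into no order at this position, even with an aromatic ring added to the range of groups. Nothing available bears on the reason for this flat result.

Open, from the compounds shown here alone, is whether a phenyl ring, or a longer chain ending in an amine or a carboxylic acid, on this nitrogen would give a step beyond the scatter. Also open, going by these compounds, is whether any change elsewhere on the shared core would do so.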